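Replacing 2,3-dichlorophenyl with 4-hydroxyphenyl in compound 4

A few compounds are considered here, and "the series" means these few. Any claim that something is new, unique, unknown or untested is made for them only; others in the source may bear on it.

For the measured compounds named here, in a functional assay on A549 cells (Homo sapiens) for antiproliferative activity, read by MTT assay, with a stated time of 72 h (on this read-out higher numbers stand for weaker inhibition and lower numbers for stronger inhibition), compound 3 `O=C(N/N=C/c1cccc(Cl)c1Cl)Nc1ccc(Oc2ccnc3[nH]ccc23)c(F)c1` has no single number, its result being "not active" (no number reported) without any figure, so no step can be counted from it. The change to compound 4 `O=C(N/N=C/c1ccc(O)cc1)Nc1ccc(Oc2ccnc3[nH]ccc23)c(F)c1` is 4-hydroxyphenyl in place of 2,3-dichlorophenyl on a carbon with a double bond to nitrogen with 4-hydroxyphenyl in place of 2,3-dichlorophenyl on a carbon with a double bond to nitrogen. Going by the values given here, only one measured step lies nearby: compound 1 `O=C(N/N=C/c1ccc(F)cc1)Nc1ccc(Oc2ccnc3[nH]ccc23)c(F)c1` gives 680 nM and compound 2 `N#Cc1ccc(/C=N/NC(=O)Nc2ccc(Oc3ccnc4[nH]ccc34)c(F)c2)cc1` gives 1360 nM on the same read-out. That step, a 2.0-fold higher number from compound 1 to compound 2 (0.30 log units; within the scatter) and so within the scatter, concerns cyano and fluoro and only bears on this change indirectly. A number of similar size is therefore expected, though a result without a number remains possible. For compound 4 the estimated value is 1500 nM with an expected range from 500 nM to 6000 nM as its bounds.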

Compound 4, half-maximal inhibitory concentration: 3760 nM
For compound 4 the middle estimate is 2.5-fold (0.40 log units) below the measured one; measured number inside the range.
By their numbers in this assay, from the lowest: compounds 1 and 2 (each within the scatter of the next); then compound 4.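

Compound 4 gives a figure in this assay where compound 3 has none, so the step between them cannot be read. Among the groups on this carbon with a double bond to nitrogen, 4-hydroxyphenyl is the first to separate beyond the scatter from the other measured phenyl groups, in two modest steps (a 2.8-fold higher number from compound 2 to compound 4 (0.44 log units; beyond the scatter) and a 5.5-fold higher number from compound 1 to compound 4 (0.74 log units; beyond the scatter)).

On these data alone, whether an amine or a methoxy group in place of the hydroxy would give a figure like that of compound 4 stays open. Nothing given here explains these differences.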